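The source may hold more compounds than are shown below. What is called first, only, known or untested is meant among the compounds shown, and "the series" means these compounds.

Measured in a functional assay for activation of Alpha-1B adrenergic receptor (Homo sapiens), read by calcium flux; on this read-out lower numbers stand for smaller maximal responses and higher numbers for larger maximal responses:
compound 1 `c1ccc(-c2cnccn2)c(OCC2=NCCN2)c1` gives 46%
compound 2 `c1c[nH]c(-c2ccccc2OCC2=NCCN2)c1` gives 104%
compound 3 `c1ccc(-c2ccoc2)c(OCC2=NCCN2)c1` gives 111%

Compound 1 stands lowest of the three values. The nearest is a number 58 percentage points higher from compound 1 to compound 2 (beyond the scatter), the furthest a number 65 percentage points higher from compound 1 to compound 3 (beyond the scatter), while between the other two there is only a number 7 percentage points higher from compound 2 to compound 3 (within the scatter).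

Compound 4 `c1ccc(-c2ccns2)c(OCC2=NCCN2)c1` is not yet measured. It differs from compound 1 thus: 1,2-thiazol-5-yl in place of pyrazin-2-yl on an aromatic carbon. Both recorded steps away from pyrazin-2-yl, a number 58 percentage points higher from compound 1 to compound 2 (beyond the scatter) and a number 65 percentage points higher from compound 1 to compound 3 (beyond the scatter), put one five-membered aromatic ring in its place and were large in the same direction. The present change also enters one five-membered aromatic ring with 2 hetero atoms, so compound 4 is expected to move by a number 49 percentage points higher from compound 1 to compound 4 (beyond the scatter) in this assay . Compound 4 is estimated at 95%, in a range from 65% to 120%.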

Compound 4, largest response reached (reported as maximum), in percent of the reference or control that the assay uses: 56%
The estimate for compound 4 lay 39 percentage points above the measured number, and the stated range ends above it.
By their numbers in this assay, from the lowest: compounds 1 and 4 (each within the scatter of the next); then compounds 2 and 3 (each within the scatter of the next).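

At this position, on an aromatic carbon of the six-membered ring, a five-membered aromatic ring does not by itself carry the large response in this assay: 1,2-thiazol-5-yl in place of pyrazin-2-yl gives a number 10 percentage points higher from compound 1 to compound 4 (within the scatter). The identity of the five-membered ring therefore matters, with a number 55 percentage points lower from compound 3 to compound 4 (beyond the scatter) and a number 48 percentage points lower from compound 2 to compound 4 (beyond the scatter). No measured evidence accounts for this split among the five-membered rings. Open, going by these compounds, is where a thiophen-2-yl group, with sulfur but no ring nitrogen, would fall at this position: with compound 4 or with compound 2 and compound 3.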